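Replacing Cyclohexyl with Butyl on a Fused Aromatic Core

The source may hold more compounds than are shown below. What is called first, only, known or untested is meant among the compounds shown, and "the series" means these compounds.

Measured compounds:
compound 1, `COc1ccc2ncc(-c3nn[nH]n3)cc2c1`, 10 mg/kg
compound 2, `c1nc2ccc(C3CCCCC3)cc2cc1-c1nn[nH]n1`, 5 mg/kg

In a functional assay on the whole organism (strain Sprague-Dawley) for inhibition, with Rattus norvegicus as the target (a higher number here means that more compound is needed for the effect, a lower number that less compound is needed), compound 2 has the lowest of the two numbers, and its nearest neighbour is compound 1, the step being a 2.0-fold lower number from compound 1 to compound 2 (0.30 log units; within the scatter). Compound 3, `CCCCc1ccc2ncc(-c3nn[nH]n3)cc2c1`, has not yet been tested in this assay. It differs from compound 2 by butyl in place of cyclohexyl on an aromatic carbon. Going by the values given here, no measured step bears on this change directly; the only step known is the one from compound 1 to compound 2, which lies within the scatter. The expected step is therefore no change at the digits printed from compound 2 to compound 3 (within the scatter). Compound 3 is estimated at 5 mg/kg, within 2.5 mg/kg to 10 mg/kg.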

Compound 3, minimum effective dose: 5 mg/kg
Compound 3: the middle estimate sits on the measured number at the digits printed, and the stated range covers the measured number.
By their numbers in this assay, from the lowest: compounds 2, 3 and 1 (each within the scatter of the next).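

In this assay, an open butyl chain on this aromatic carbon does as well as the cyclohexyl ring, with no change at the digits printed from compound 2 to compound 3 (within the scatter), so among these compounds the ring itself is not needed at this position. Butyl in place of methoxy also stays within the scatter, with a 2.0-fold lower number from compound 1 to compound 3 (0.30 log units; within the scatter), so the three groups cannot be told apart here. Nothing available explains this result.
On these data alone, whether a longer chain, an amine or a carboxylic acid on this carbon would also stay within the scatter remains open.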